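A Nitrogen Substituent Swap: Allyl to 4-Bromobenzyl

The source may report more compounds than this note shows. Statements on the series, on what has been measured and on what is new or still open speak of the compounds shown alone.

Compound 1: `Cc1ccc(-c2ccc3c(c2)C(=O)C(=O)N3)cc1` — in a functional assay on K562 cells (Homo sapiens) for antiproliferative activity, read by MTT assay, with a stated time of 48 h (a higher number here means a weaker inhibitor, a lower number a stronger inhibitor), compound 1 reaches only the limit > 10000 nM.
Compound 2: `C=CCN1C(=O)C(=O)c2cc(-c3ccc(OC)cc3)ccc21` — in this assay compound 2 gives 390 nM.
Compound 3: `COc1ccc(-c2ccc3c(c2)C(=O)C(=O)N3c2ccc(OC)cc2)cc1` — in this assay compound 3 reaches only the limit > 10000 nM.

For the measured compounds named here, compound 2 holds the only number in this assay; the other two values shown are limits (the limit of > 10000 nM in this assay, at which 2 of the 3 values shown sit). The unmeasured compound 4, `COc1ccc(-c2ccc3c(c2)C(=O)C(=O)N3Cc2ccc(Br)cc2)cc1`, differs from compound 2 by 4-bromophenyl in place of vinyl on a saturated chain carbon bound to an amide-type nitrogen in a ring. Going by the values given here, the one measured step that bears on this is an at least 25-fold higher number from compound 2 to compound 3 (1.40 log units; beyond the scatter), in which an aromatic ring was placed directly on the amide-type nitrogen in the ring. Compound 4 instead keeps the aromatic ring on a saturated chain carbon bound to that nitrogen, so the measured step is only a partial guide. Compound 4 is therefore expected to be weaker than compound 2, by a step estimated as a 3.1-fold higher number from compound 2 to compound 4 (0.49 log units; beyond the scatter), smaller than the loss seen with compound 3. The value of compound 4 in this assay is estimated at 1200 nM, with a range of 300 nM to 8000 nM.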

Compound 4, half-maximal inhibitory concentration: 100 nM
Compound 4: the middle estimate sits 12-fold (1.08 log units) above what was measured; measured number below the stated range.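

In this assay, an aromatic ring carried on a saturated chain carbon bound to the amide-type nitrogen in the ring is not a loss, as allyl to 4-bromobenzyl gives a 3.9-fold lower number from compound 2 to compound 4 (0.59 log units; beyond the scatter). Compound 3 had shown only that an aromatic ring set directly on that nitrogen goes with a loss, whereas 4-bromobenzyl in place of 4-methoxyphenyl gives an at least 100-fold lower number from compound 3 to compound 4 (2.00 log units; beyond the scatter), a change that alters both the link to the ring and the group on it. The size of that step is open-ended, since compound 3 holds a limit and not a number: the limit of > 10000 nM in this assay, at which 2 of the 4 values shown sit.

On these data alone, what stays open is whether the gain belongs to the bromine or to the benzyl link, which plain benzyl or 4-methoxybenzyl on this nitrogen would separate. A longer chain such as 2-phenylethyl, or an amine at the end of the chain, also remains untested among the compounds shown.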